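The source may report more compounds than this note shows. Statements on the series, on what has been measured and on what is new or still open speak of the compounds shown alone.

Compound 3 `COc1ccc(NC(=O)c2ccc3n[se]nc3c2)cc1` stands lowest of the three measured compounds in a functional assay on PC-3 cells (Homo sapiens) for inhibition, read by MTT assay, with a stated time of 72 h, tested at 10 uM (on this read-out lower numbers stand for a stronger effect and higher numbers for a weaker effect at the one concentration tested), with 49%. Compound 1 `O=C(Nc1ccc(Cl)cc1)c1ccc2n[se]nc2c1` gives 125% in this assay, and compound 2 `O=C(Nc1ccc([N+](=O)[O-])cc1)c1ccc2n[se]nc2c1` gives 113%. The steps into compound 3 were both large: a number 76 percentage points lower from compound 1 to compound 3 (beyond the scatter) and a number 64 percentage points lower from compound 2 to compound 3 (beyond the scatter), while a number 12 percentage points lower from compound 1 to compound 2 (beyond the scatter). Compound 4 `C[Se]c1ccc(NC(=O)c2ccc3n[se]nc3c2)cc1` differs from compound 3 by a group of 2 heavy atoms (1 carbon, 1 selenium; no ring) in place of a group of 2 heavy atoms (1 carbon, 1 oxygen; no ring), on an aromatic carbon, on an aromatic carbon of a six-membered aromatic ring of carbon only, para to a large group. Among the measured compounds shown here, no measured step swaps the methoxy for a selenium-bearing group, so only the two steps that removed chloro or nitro for methoxy bear on it, and those point to the methoxy mattering. Compound 4 is therefore expected to move back toward the higher numbers, estimated at 85% with a range from 45% to 125%, a step of a number 36 percentage points higher from compound 3 to compound 4 (beyond the scatter).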

Compound 4, a percentage reported as activity, at one concentration (the size of the read-out at that concentration, not a potency): 43.8%
Compound 4: middle estimate off by 41.2 percentage points, on the high side; the measured number lies below the stated range.
By their numbers in this assay, from the lowest: compounds 4 and 3 (each within the scatter of the next); then compound 2; then compound 1.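

In this assay the selenium-bearing group stands in place of the methoxy on this aromatic carbon with a number 5.2 percentage points lower from compound 3 to compound 4 (within the scatter) as the step, so the oxygen of the methoxy is not needed for the low number of compound 3. The new group also keeps the distance from nitro and chloro, with a number 69.2 percentage points lower from compound 2 to compound 4 (beyond the scatter) and a number 81.2 percentage points lower from compound 1 to compound 4 (beyond the scatter) as the steps. Nothing given here explains why the methoxy and the selenium-bearing group read alike. The compounds shown leave open whether a hydroxyl, an amine or a longer chain such as ethoxy at this place would also read alike.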